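Moving the chlorine on the benzyl ring of a sulfonamide

The source may hold more compounds than are shown below. What is called first, only, known or untested is meant among the compounds shown, and "the series" means these compounds.

Measured so far:
Compound 1 `O=S(=O)(NCCCNCc1ccccc1Cl)c1cc(C(F)(F)F)cc(C(F)(F)F)c1` — 11000 nM
Compound 2 `O=S(=O)(NCCCCCCNCc1ccc(Br)cc1)c1ccc(C(F)(F)F)cc1` — 3830 nM
Compound 3 `CCCCc1ccc(S(=O)(=O)NCCCCCCNCc2ccc(Br)cc2)cc1` — 5700 nM

All three compounds were tested in a functional assay on MIA PaCa-2 cells (Homo sapiens) for inhibition, read by MTT assay, with a stated time of 72 h; on this read-out higher numbers stand for weaker inhibition of growth and lower numbers for stronger inhibition of growth. Compound 1 gives 11000 nM, the highest number of the three. Its gap to compound 3 is within the scatter, while its gap to compound 2 lies beyond it. Among the measured compounds shown here, the one step that can be read between measured compounds, a 1.5-fold higher number from compound 2 to compound 3 (0.17 log units; within the scatter), changes the group on the sulfonyl-bearing aromatic ring and leaves the result within the scatter.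

Compound 4 `O=S(=O)(NCCCNCc1cccc(Cl)c1)c1cc(C(F)(F)F)cc(C(F)(F)F)c1` is the compound not yet measured. It differs from compound 1 in this way: 3-chlorophenyl in place of 2-chlorophenyl on a saturated chain carbon bound to an amine nitrogen

For the measured compounds named here, no measured pair shows what moving the chlorine on the 2-chlorobenzyl group to give a 3-chlorobenzyl group does; the step between compound 2 and compound 3 concerns a different part of the molecule, and compounds 2 and 3 differ from compound 1 in chain length and in the sulfonyl-bearing ring as well. Without a directly comparable pair, the expectation is that compound 4 stays close to compound 1, with no step beyond the scatter, so the expected step is no change at the digits printed from compound 1 to compound 4 (within the scatter). The estimate for compound 4 in this assay is 11000 nM, with a range from 4000 nM to 30000 nM.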

Compound 4, concentration for 50% growth inhibition: 4400 nM
For compound 4 the middle estimate is 2.5-fold (0.40 log units) above the measured one; measured number inside the range.
By their numbers in this assay, from the lowest: compounds 2, 4, 3 and 1 (each within the scatter of the next, the first and the last beyond it).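

In this assay, among the compounds shown here, the change from 2-chlorobenzyl to 3-chlorobenzyl gives a 2.5-fold lower number from compound 1 to compound 4 (0.40 log units; beyond the scatter) and is the first step in this set to go beyond the usual scatter. The two compounds have the same atoms joined differently, so this pair shows that the place of the chlorine on the benzyl ring alone can shift the result, though only modestly and only on the core of compound 1; the earlier step concerned the sulfonyl-bearing ring and stayed within the scatter. Nothing available here accounts for the shift, and the reason for it remains unknown.

The compounds shown leave open whether a plain benzyl group with no chlorine, or a benzyl group carrying a fluorine or a methyl group in place of the chlorine, would give a number nearer to that of compound 1 or that of compound 4. For the compounds shown here, they also leave open whether moving a halogen on the benzyl ring would have a similar effect on a longer chain, such as the one in compound 2 and compound 3.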